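The source may report more compounds than this note shows. Statements on the series, on what has been measured and on what is new or still open speak of the compounds shown alone.

Measured compounds:
Compound 1 `O=c1ccoc2cc(OCc3cn(Cc4ccccc4Br)nn3)ccc12`. In a functional assay on SGC-7901 cells (Homo sapiens) for cytotoxicity, read by MTT assay, with a stated time of 48 h (on this read-out higher numbers stand for weaker inhibition and lower numbers for stronger inhibition), compound 1 gives only a limit, > 100000 nM.
Compound 2 `O=c1ccoc2cc(OCc3cn(Cc4cccc(Br)c4)nn3)ccc12`. In this assay compound 2 likewise gives only a limit, > 100000 nM.
Compound 3 `O=c1ccoc2cc(OCc3cn(Cc4ccc(Cl)cc4Cl)nn3)ccc12`. In this assay compound 3 gives only a limit, > 100000 nM.

Compound 2 thus stands nowhere in particular on these numbers: its value is a limit, as are the two others shown, so that all three sit at the limit of > 100000 nM in this assay, at which 3 of the 3 values shown sit. The steps among them, a step that the two limits leave unreadable from compound 1 to compound 2, a step that the two limits leave unreadable from compound 1 to compound 3 and a step that the two limits leave unreadable from compound 2 to compound 3, are therefore of unreadable size, and none tells whether a change of the benzyl-borne halogen pattern moves potency at all.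

Compound 4 `O=c1ccoc2cc(OCc3cn(Cc4ccc(F)cc4)nn3)ccc12` differs from compound 2 by 4-fluorophenyl in place of 3-bromophenyl on a saturated chain carbon bound to an aromatic nitrogen. The measured steps that bear on this change, all three of them, leave the size unreadable; what they do show is that three different halogen-substituted phenyl groups at this position all fail to reach a readable value in this assay. No step beyond the scatter can be expected on this evidence, and a fourth limit is the most likely outcome. Compound 4 is therefore estimated at 150000 nM, with a range from 60000 nM to 400000 nM. The step this estimate implies is expected to be a step that the limit leaves unreadable from compound 2 to compound 4.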

Compound 4, half-maximal inhibitory concentration: > 100000 nM
Compound 4: a limit, no number; the forecaster's own chance of this, stated with the estimate: 85%; the middle value does not contradict the limit.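

In this assay compound 4 also gives only the limit > 100000 nM and none of its steps from compound 1, compound 2 or compound 3 can be read: the limit of > 100000 nM in this assay, at which 4 of the 4 values shown sit. The compounds shown leave open whether changing the halogen-substituted phenyl group moves potency at all.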